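A few compounds are considered here, and "the series" means these few. Any claim that something is new, unique, unknown or untested is made for them only; others in the source may bear on it.

Measured compounds in a physicochemical assay for solubility, with a stated time of 18 h, at pH 7.4; on this read-out lower numbers stand for lower solubility and higher numbers for higher solubility:
compound 1, `COc1ccccc1Oc1ccc2c(NCCCNCc3ccco3)ccnc2c1`: 14500 nM
compound 2, `COc1cccc(CNCCCNc2ccnc3cc(Cc4ccccc4)ccc23)c1O`: 4200 nM
compound 3, `COc1ccc(F)cc1CNCCCNc1ccnc2cc(CCc3ccccc3)ccc12`: 4200 nM

Compound 1 holds the highest of the three numbers in this assay. Compound 2 and compound 3 each give a number that lies well below it, beyond the usual scatter, and the two of them give the same number. Going by the values given here, no two of the measured compounds differ in only one place, so no single step between them is known.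

Compound 4, `COc1ccc(-c2ccc3c(NCCCNCc4ccco4)ccnc3c2)cc1`, has not yet been measured. It differs from compound 1 in one place: 4-methoxyphenyl in place of 2-methoxyphenoxy on an aromatic carbon. Among the compounds with values here, nothing among the measured compounds mirrors this change. A modest step downward in this assay, beyond the scatter but not large, is expected from compound 1 to compound 4, namely a 2.4-fold lower number from compound 1 to compound 4 (0.38 log units; beyond the scatter). Compound 4 is therefore estimated at 6000 nM, within a range from 2000 nM to 18000 nM.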

Compound 4, solubility: 32000 nM
Beside the measured number, compound 4's estimate is 5.3-fold (0.73 log units) below it; the measured number lies above the stated range.
By their numbers in this assay, from the lowest: compounds 2 and 3 (each within the scatter of the next); then compound 1; then compound 4.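

In this assay, going by these compounds alone, there is now a first single-place step at this aromatic carbon: 4-methoxyphenyl in place of 2-methoxyphenoxy gives a 2.2-fold higher number from compound 1 to compound 4 (0.34 log units; beyond the scatter) as a modest rise beyond the scatter. Compound 4 thus shows that this position of the core can take this change without a fall in the number. Nothing at hand bears on the reason for the rise. Going by these compounds, whether the step follows the loss of the ether oxygen or the shift of the methoxy group stays open, and a 4-methoxyphenoxy or a 2-methoxyphenyl group would separate the two. On these data alone, how an amine or a carboxylic acid at this position would read is also open.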